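The source may hold more compounds than are shown below. What is called first, only, known or untested is meant among the compounds shown, and "the series" means these compounds.

Measured compounds:
Compound 1, `Oc1ccc(-c2cc(-c3ccc(Cl)cc3)nc(-c3cccnc3)c2)cc1`, with 18.8% in an assay on isolated protein for inhibition of DNA topoisomerase 1 (Homo sapiens), with a stated time of 30 min, tested at 100 uM; on this read-out lower numbers stand for a weaker effect and higher numbers for a stronger effect at the one concentration tested
Compound 2, `Oc1cccc(-c2cc(-c3ccc(Cl)cc3)nc(-c3ccsc3)c2)c1`, with 11.7%
Compound 3, `Oc1ccc(-c2cc(-c3cccnc3)nc(-c3cccc(Cl)c3)c2)cc1`, with 55.2%

Of the compounds shown here, three sharing a core carrying a chlorophenyl group have been measured in this assay. Compound 1 and compound 2 give numbers that lie within the usual scatter of each other, so nothing can be said about an order between them. The difference between the core of compound 1 and the core of compound 2 is not broken down here. Compound 3 stands apart: its value is beyond the scatter from both compound 1 and compound 2.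

Among the measured compounds shown here, the one counted step is 3-chlorophenyl in place of 4-chlorophenyl on an aromatic carbon, which gave a number 36.4 percentage points higher from compound 1 to compound 3 (beyond the scatter).

Compound 4, `Oc1cccc(-c2cc(-c3ccsc3)nc(-c3cccc(Cl)c3)c2)c1`, has not yet been measured. It relates to compound 2 as compound 3 relates to compound 1: 3-chlorophenyl in place of 4-chlorophenyl on an aromatic carbon. The two places are not the same word for word, since in the first case the changed carbon is meta to a 4-hydroxyphenyl group and meta to a pyridin-3-yl group, whereas in the second it is meta to a 3-hydroxyphenyl group and meta to a thiophen-3-yl group, so this is the same kind of change rather than the same change. For the measured compounds named here, only one earlier example of it exists, and its surroundings differ.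

For compound 4 a step of a number 28.3 percentage points higher from compound 2 to compound 4 (beyond the scatter) is therefore expected, somewhat smaller than the step seen from compound 1 to compound 3, because the earlier step of a number 36.4 percentage points higher from compound 1 to compound 3 (beyond the scatter) was large, while the differing surroundings leave the transfer uncertain. The estimate for compound 4 is 40%, with a range from 15% to 65%.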

Compound 4, a percentage reported as inhibition, at one concentration (the size of the read-out at that concentration, not a potency): 26.2%
Beside the measured number, compound 4's estimate is 13.8 percentage points above it, within the range that was stated.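

On the core of compound 2, 3-chlorophenyl in place of 4-chlorophenyl gave a number 14.5 percentage points higher from compound 2 to compound 4 (beyond the scatter) in this assay, so the change points the same way on both cores shown. Its size, however, did not carry over from one core to the other: the same change on two cores in this assay, a number 36.4 percentage points higher (beyond the scatter) from compound 1 to compound 3 and a number 14.5 percentage points higher (beyond the scatter) from compound 2 to compound 4, 21.9 percentage points apart, beyond the scatter of two such steps The direction of the change therefore held in both available cases, but the size seen on one core could not be read across to the other, and two cores give no rule for a third; the core of compound 1 carries 4-hydroxyphenyl and pyridin-3-yl groups where the core of compound 2 carries 3-hydroxyphenyl and thiophen-3-yl groups, so these compounds cannot say which of the two differences goes with the smaller step.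

The compounds shown leave open how large the step would be on a core that pairs 4-hydroxyphenyl with thiophen-3-yl, or 3-hydroxyphenyl with pyridin-3-yl, which would separate those two differences. They also leave open whether the same change would hold with an amine or a methoxy group in place of the hydroxyl, or whether a fluorophenyl or bromophenyl group would behave as the chlorophenyl groups do.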